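Removing One Methoxy Group: Expectations for Compound 3

This account rests on a few compounds, and the source may have more. Where it says the series, first, only, none or still open, it means among the compounds named here.

Measured so far:
compound 1: `CSc1ccc(/C=C/C=C/C(=O)N2CCCCC2)cc1`, 11.8%
compound 2: `COc1ccc(/C=C/C=C/C(=O)N2CCCCC2)cc1OC`, 51.9%

In an assay for inhibition of Polyunsaturated fatty acid 5-lipoxygenase (Homo sapiens), read by spectrophotometry, tested at 20 uM (a lower number here means less inhibition, a higher number more inhibition at the concentration tested (going by the name of the read-out)), compound 2 stands highest of the two numbers measured; compound 1 lies below it by a gap that is beyond the usual scatter. Within the data shown here, the two measured compounds differ in more than one place, so no single-change step between them is available, and only their two values can be set side by side.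

Compound 3, `COc1ccc(/C=C/C=C/C(=O)N2CCCCC2)cc1`, differs from compound 2 by hydrogen in place of methoxy on an aromatic carbon. Among the measured compounds shown here, with no measured step of this kind to lean on, the expectation rests on the value of compound 2 and on the loss of one methoxy group. A step of a number 19.9 percentage points lower from compound 2 to compound 3 (beyond the scatter) is expected, a fall of moderate size, beyond the scatter but not back to the level of compound 1. Compound 3 is estimated at 32%, with a range from 12% to 52%.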

Compound 3, a percentage reported as inhibition, at one concentration (the size of the read-out at that concentration, not a potency): 42.6%
Beside the measured number, compound 3's estimate is 10.6 percentage points below it; the range from low to high includes it.
By their numbers in this assay, from the lowest: compound 1; then compounds 3 and 2 (each within the scatter of the next).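

In this assay, hydrogen in place of methoxy, on the aromatic carbon ortho to a methoxy group, gives a number 9.3 percentage points lower from compound 2 to compound 3 (within the scatter), so this change does not separate the two compounds and the second methoxy group is not shown to matter at this position. Methoxy in place of methylsulfanyl on an aromatic carbon gives a number 30.8 percentage points higher from compound 1 to compound 3 (beyond the scatter), which means that the wide gap between the first two compounds can now be tied to this single exchange rather than to the added methoxy group. Nothing available here bears on the reason for either result.

On these data alone, whether a hydroxyl group, an amine or a longer alkoxy chain on the same aromatic carbon would stand apart from hydrogen and methoxy remains open. So does the outcome of hydrogen in place of the remaining methoxy group.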